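The compounds below may be only part of what the source reports. "The series", "measured", "known", "first", "only" and "open" are said of these compounds alone.

Measured in a functional assay on DU-145 cells (Homo sapiens) for inhibition, read by trypan blue exclusion, with a stated time of 96 h; a lower number here means a stronger inhibitor of growth, a higher number a weaker inhibitor of growth:
- compound 1 `O=C(/C(=C\c1c[nH]c2ccccc12)Sc1ccc(Br)cc1)c1ccc(Br)cc1`: 1000 nM
- compound 2 `O=C(/C(=C\c1ccc(F)cc1F)Sc1ccc(Br)cc1)c1ccc(Br)cc1`: 1000 nM

Within the data shown here, compound 2 stands level with compound 1, its nearest measured neighbour, and no other measured compound brackets it. Compound 3 `O=C(/C(=C\c1ccc(F)cc1F)Sc1ccc(Br)cc1)c1ccc(Cl)cc1` differs from compound 2 in one place: chloro in place of bromo on an aromatic carbon. In words, this is chloro in place of bromo on an aromatic carbon, and the same difference reads (4-bromophenyl)carbonyl to (4-chlorophenyl)carbonyl. Among the measured compounds shown here, the only measured step is no change at the digits printed from compound 1 to compound 2 (within the scatter). For the measured compounds named here, it replaced 1H-indol-3-yl with 2,4-difluorophenyl, so it bears only indirectly on this change, and no measured step touches the bromo position. With this single flat step as the guide, no direction can be assigned and no shift beyond the scatter is expected in this assay. The expected outcome is no change at the digits printed from compound 2 to compound 3 (within the scatter). For compound 3 the estimated value is 1000 nM, with an expected range of 400 nM to 2500 nM.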

Compound 3, concentration for 50% growth inhibition: 1000 nM
The estimate for compound 3 equals the measured number at the digits printed; low and high end bracket the measured number.
By their numbers in this assay, from the lowest: compounds 1, 2 and 3 (each within the scatter of the next).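

In this assay this position now has its first direct reading, no change at the digits printed from compound 2 to compound 3 (within the scatter), so with the rest of compound 2 held fixed, the (4-chlorophenyl)carbonyl and (4-bromophenyl)carbonyl groups cannot be told apart. The earlier step concerned only the exchange of 1H-indol-3-yl for 2,4-difluorophenyl, whereas this one shows that exchanging one halogen for the other at this position gives no reading beyond the scatter. No measurement at hand accounts for this flat result.

On these data alone, whether this position accepts anything other than a halogen remains open, and a methoxy group, an amine or a carboxylic acid in place of the chloro would test that. Also open, as far as these compounds go, is whether the same exchange reads alike when 1H-indol-3-yl replaces 2,4-difluorophenyl, or when it is made on the other 4-bromophenyl group.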